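Replacing 3-nitrophenyl with 2,4-dihydroxyphenyl on a shared core

A few compounds are considered here, and "the series" means these few. Any claim that something is new, unique, unknown or untested is made for them only; others in the source may bear on it.

Compound 1 `O=C(COc1cccc2ccccc12)N/N=C/c1ccc(Cl)cc1` gives 100 ug/mL
Compound 2 `C/C(=N\NC(=O)COc1cccc2ccccc12)c1cccc([N+](=O)[O-])c1` gives 10.5 ug/mL

Both numbers come from an ADME assay on HEL cells (Homo sapiens) for cytotoxicity (on this read-out higher numbers stand for lower toxicity in this test and lower numbers for higher toxicity in this test), and they lie apart by more than the usual scatter of repeated measurements. Compound 2 holds the lower of the two numbers. The two compounds differ in more than one place, so no single structural change can be read from their gap.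

Compound 3 (`C/C(=N\NC(=O)COc1cccc2ccccc12)c1ccc(O)cc1O`) has not yet been measured. It keeps the rest of compound 2 and carries 2,4-dihydroxyphenyl in place of 3-nitrophenyl on a carbon with a double bond to nitrogen.

With no measured single change to lean on, the expectation rests on the spread of the two values alone. Compound 2 (10.5 ug/mL) sits at the low end and compound 1 (100 ug/mL) at the high end, so a new compound seems more likely to land upward than further down. A moderate rise is expected (a 2.7-fold higher number from compound 2 to compound 3 (0.43 log units; beyond the scatter)), though the uncertainty is wide. For compound 3 the estimated value is 28 ug/mL (expected range 8 ug/mL to 100 ug/mL).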

Compound 3, half-maximal cytotoxic concentration: 74.8 ug/mL
The estimate for compound 3 lay 2.7-fold (0.43 log units) below the measured number; measured number inside the range.
By their numbers in this assay, from the lowest: compound 2; then compounds 3 and 1 (each within the scatter of the next).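

In this assay, among the compounds shown here, putting 2,4-dihydroxyphenyl in place of 3-nitrophenyl on a carbon with a double bond to nitrogen gives a 7.1-fold higher number from compound 2 to compound 3 (0.85 log units; beyond the scatter), and this is the first single change that can be read. With the rest of compound 2 kept, the group at this position alone moves the number by more than the usual scatter, in the direction of lower toxicity in this test. The swap alters several things at once, since the entering group has 2 hydrogen-bond donors where the leaving group has 0, and no measurement shown ties the step to any one of these differences.

From the compounds shown here alone, what stays open is whether the gain comes from losing the nitro group, from gaining the two hydroxyl groups, or from both. An unsubstituted phenyl, a phenyl with a single hydroxyl, or a phenyl carrying methoxy groups or an amine at this place would help to separate these possibilities.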